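Cytotoxicity of a trifluoroethoxy analogue expected to stay low

The source may report more compounds than this note shows. Statements on the series, on what has been measured and on what is new or still open speak of the compounds shown alone.

Compound 1 `CC(C)CSc1nc(N)nc2c1ncn2/C=C1/CC1(CO)CO` carries isobutylsulfanyl on the shared core. Among the measured compounds shown here, in an ADME assay on CCRF-HSB-2 cells (Homo sapiens) for cytotoxicity, with a stated time of 7 days (on this read-out lower numbers stand for higher toxicity in this test and higher numbers for lower toxicity in this test), compound 1 gives 60000 nM, the only number among the three values shown. Compound 2 `CC(C)CNc1nc(N)nc2c1ncn2/C=C1/CC1(CO)CO` reaches only a limit of the assay, > 20000 nM. Compound 3 `CCCCCOc1nc(N)nc2c1ncn2/C=C1/CC1(CO)CO` likewise stops at a limit, > 20000 nM. Accordingly the steps a step that the limit leaves unreadable from compound 1 to compound 2 and a step that the limit leaves unreadable from compound 1 to compound 3 cannot be read; their size is hidden by the limit of > 20000 nM in this assay, at which 2 of the 3 values shown sit. Compound 4 `Nc1nc(OCC(F)(F)F)c2ncn(/C=C3/CC3(CO)CO)c2n1` differs from compound 1 by 2,2,2-trifluoroethoxy in place of isobutylsulfanyl on an aromatic carbon. Both measured steps leave an exchange at this carbon unreadable in size and give no sign of a step in either direction. Compound 4 is therefore expected to remain weakly cytotoxic, with no change at the digits printed from compound 1 to compound 4 (within the scatter) estimated as no step beyond the scatter. Compound 4 is estimated at 60000 nM, within 20000 nM to 200000 nM.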

Compound 4, half-maximal cytotoxic concentration: > 20000 nM
Compound 4 was reported as a limit; the forecaster's own chance of this, stated with the estimate: 60%; the middle value lies beyond the limit too.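

Compound 4 also stops at a limit of the assay, so no step between it and compound 1, compound 2 or compound 3 can be read: the limit of > 20000 nM in this assay, at which 3 of the 4 values shown sit.

The compounds shown leave open how compound 2, compound 3 and compound 4 truly compare with compound 1 in this assay.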